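Sulfonyl aryl variation: notes on compounds 1 to 4

A few compounds are considered here, and "the series" means these few. Any claim that something is new, unique, unknown or untested is made for them only; others in the source may bear on it.

Measured so far in a functional assay on DLD-1 cells (Homo sapiens) for antiproliferative activity, read by CellTiter-Glo, with a stated time of 72 h; on this read-out higher numbers stand for weaker inhibition and lower numbers for stronger inhibition:
compound 1 `Cc1noc(C)c1S(=O)(=O)N1CCC(N2CCC(C)CC2)CC1`: > 5000 nM
compound 2 `Cc1cccc(S(=O)(=O)N2CCC(N3CCC(C)CC3)CC2)c1`: 25 nM
compound 3 `Cc1nc(Cl)sc1S(=O)(=O)N1CCC(N2CCC(C)CC2)CC1`: 1.6 nM

The value given for compound 1 is a limit of this assay and not a number, as recorded in the limit of > 5000 nM in this assay, at which 1 of the 3 values shown sits. Among the two numbers, compound 2 stands highest; its nearest neighbour is compound 3, with a 16-fold lower number from compound 2 to compound 3 (1.19 log units; beyond the scatter). Compound 2 also sits far from the limit of compound 1, shown by an at least 200-fold lower number from compound 1 to compound 2 (2.30 log units; beyond the scatter), and compound 3 further still, by an at least 3100-fold lower number from compound 1 to compound 3 (3.49 log units; beyond the scatter).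

Compound 4 `CC1CCN(C2CCN(S(=O)(=O)c3cccc(-c4ccccc4)c3)CC2)CC1` is not yet measured. It differs from compound 2 by phenyl in place of methyl on an aromatic carbon. All three measured steps exchange the whole group on the sulfonyl sulfur, and each of them is large; none of them adds a group to the 3-methylphenyl of compound 2 while keeping that ring. They show that this assay responds strongly to what sits on the sulfonyl sulfur, but they give no direction for the present change. The expected step for compound 4 is therefore modest and uncertain in sign, a 1.2-fold higher number from compound 2 to compound 4 (0.08 log units; within the scatter). Compound 4 is estimated at 30 nM in this assay, within 5 nM to 200 nM.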

Compound 4, half-maximal inhibitory concentration: 2 nM
Compound 4: middle estimate off by 15-fold (1.18 log units), on the high side; measured number outside the range, below it.
By their numbers in this assay, from the lowest: compounds 3 and 4 (each within the scatter of the next); then compound 2. At a limit, above all of these: compound 1.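

Keeping the aromatic ring of compound 2 and changing only the group it carries moves the number in this assay strongly, with phenyl in place of methyl giving a 13-fold lower number from compound 2 to compound 4 (1.10 log units; beyond the scatter). Within the data shown here, this is the first step that leaves that ring in place, and it shows that this aromatic carbon, meta to a large group, accepts phenyl with a lower number, so the group on the sulfonyl sulfur need not be exchanged as a whole to reach the low numbers: compound 3 gives 1.6 nM and compound 4 gives 2 nM, values within the scatter of each other. Nothing at hand gives a reason for this step.

The compounds shown leave open whether phenyl itself matters here or whether another group at this place, such as benzyl, pyridyl or a longer chain like butyl, would give a similar number. Going by these compounds, it also stays open how a phenyl carrying an amine or a carboxylic acid would behave at this place, and whether phenyl on the 2-chloro-4-methyl-1,3-thiazol-5-yl group of compound 3 would change its number.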